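This account rests on a few compounds, and the source may have more. Where it says the series, first, only, none or still open, it means among the compounds named here.

Three compounds share one core and differ in two places. Compound 1 `COc1cc2c(Oc3ccc(NC(=O)c4nn(-c5ccccc5OC(F)(F)F)c(=O)cc4C)cc3F)ccnc2cc1OCCCN1CCCCC1` gives 190 nM in a functional assay on HT-29 cells (Homo sapiens) for inhibition, read by MTT assay, with a stated time of 72 h; a lower number here means a stronger inhibitor, a higher number a weaker inhibitor. Compound 2 `COc1cc2c(Oc3ccc(NC(=O)c4nn(-c5cccc(F)c5)c(=O)cc4C)cc3F)ccnc2cc1OCCCN1CCCC1` gives 250 nM in this assay. Compound 3 `COc1cc2c(Oc3ccc(NC(=O)c4nn(-c5cccc(F)c5)c(=O)cc4C)cc3F)ccnc2cc1OCCCN1CCCCC1` gives 290 nM in this assay, the highest of the three numbers, though its nearest neighbour is compound 2 and its furthest is compound 1, and both gaps fall within the scatter: a 1.5-fold higher number from compound 1 to compound 3 (0.18 log units; within the scatter) and a 1.2-fold higher number from compound 2 to compound 3 (0.06 log units; within the scatter).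

Compound 4 `COc1cc2c(Oc3ccc(NC(=O)c4nn(-c5ccc(Cl)cc5)c(=O)cc4C)cc3F)ccnc2cc1OCCCN1CCCCC1` has not yet been measured. It differs from compound 3 in one place: 4-chlorophenyl in place of 3-fluorophenyl on an aromatic nitrogen. For the measured compounds named here, of the two measured steps, only the one from compound 1 to compound 3 touches the same position, the group on the aromatic nitrogen, and that step, a 1.5-fold higher number from compound 1 to compound 3 (0.18 log units; within the scatter), stayed within the scatter. The step from compound 2 to compound 3 concerns the amine at the end of the chain and says nothing about this position.

On that basis no step beyond the scatter is expected from compound 3 to compound 4, a 1.1-fold lower number from compound 3 to compound 4 (0.05 log units; within the scatter). Compound 4 is therefore expected to give about 260 nM in this assay, within a range from 110 nM to 650 nM.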

Compound 4, half-maximal inhibitory concentration: 360 nM
Compound 4: middle estimate off by 1.4-fold (0.14 log units), on the low side; the range from low to high includes it.
By their numbers in this assay, from the lowest: compounds 1, 2, 3 and 4 (each within the scatter of the next).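

With 4-chlorophenyl on the aromatic nitrogen in this assay, the number moves by a 1.2-fold higher number from compound 3 to compound 4 (0.09 log units; within the scatter) and by a 1.9-fold higher number from compound 1 to compound 4 (0.28 log units; within the scatter), so a third group at this position still produces no step beyond the scatter. The change from 3-fluorophenyl to 4-chlorophenyl alters both the halogen and its place on the phenyl ring, and this single step cannot separate the two alterations. Nothing available here accounts for this result.

The compounds shown leave open whether an amine or a carboxylic acid on the phenyl ring, or a plain methyl group on the aromatic nitrogen in place of the phenyl ring, would give a step beyond the scatter. They also leave open how 4-chlorophenyl behaves alongside pyrrolidin-1-yl at the end of the chain.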